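The compounds below may be only part of what the source reports. "The series", "measured", "known", "first", "only" and "open" are said of these compounds alone.

Working notes on the series. In an ADME assay on HepG2 cells (Homo sapiens) for cytotoxicity, read by MTT assay, with a stated time of 24 h (a higher number here means that more compound is tolerated, a lower number that less compound is tolerated), compound 3 `COc1ccc(C(=O)OCCCc2cn(-c3ccnc4cc(Cl)ccc34)nn2)cc1` gives 347000 nM. Compound 2 `CC(C)(O)c1cn(-c2ccnc3cc(Cl)ccc23)nn1` gives 442000 nM in this assay. Compound 1 `Fc1ccc(-c2cn(-c3ccnc4cc(Cl)ccc34)nn2)cc1` gives > 3080000 nM in this assay, which is a limit of the assay and not a number (the limit of > 3080000 nM in this assay, at which 1 of the 3 values shown sits). Of the two numbers, compound 3 stands level with compound 2, the gap between them within the scatter. For the measured compounds named here, the only measured step, an at least 6.9-fold lower number from compound 1 to compound 2 (0.84 log units; beyond the scatter), concerns a different position of the core and does not bear on the change ahead. Compound 4 `Cc1ccc(C(=O)OCCCc2cn(-c3ccnc4cc(Cl)ccc34)nn2)cc1` differs from compound 3 by methyl in place of methoxy on an aromatic carbon. Going by the values given here, no measured step touches this position, so no shift beyond the scatter is expected. The step expected here is a 1.0-fold higher number from compound 3 to compound 4 (0.00 log units; within the scatter). For compound 4 the value is estimated at 350000 nM, expected between 170000 nM and 720000 nM.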

Compound 4, half-maximal cytotoxic concentration: > 2460000 nM
Compound 4 ended at the assay's limit (the forecaster's own chance of this, stated with the estimate: 10%); middle value at least 7.0-fold (0.84 log units) away from the limit.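

Methyl in place of methoxy on this aromatic carbon gives an at least 7.0-fold higher number from compound 3 to compound 4 (0.85 log units; beyond the scatter) in this assay, so this position of the 4-methoxyphenyl group affects the number, which no earlier step could show. Compound 4 carries a limit of the assay and not a number: the limit of > 2460000 nM in this assay, at which 1 of the 4 values shown sits.

On these data alone, the full size of this step stays open, with only its lower bound defined. As far as these compounds go, only compound 3 and compound 4 speak to this position, so it is also open whether an amine or a chlorine atom here would read with compound 3 or with compound 4.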